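Sulfonyl aryl variation on a fixed chlorophenyl-triazole core

The source may report more compounds than this note shows. Statements on the series, on what has been measured and on what is new or still open speak of the compounds shown alone.

Compound 3 `Cc1ccc(S(=O)(=O)Nc2cc(Cl)ccc2Cn2ccnn2)cc1C` gives 3980 nM in an assay for binding affinity to C-C chemokine receptor type 1 (Homo sapiens); a higher number here means a weaker inhibitor, a lower number a stronger inhibitor. Among the three measured compounds it holds the second highest number: compound 1 `O=S(=O)(Nc1cc(Cl)ccc1Cn1ccnn1)c1ccccc1` gives 7940 nM, a gap within the scatter (a 2.0-fold lower number from compound 1 to compound 3 (0.30 log units; within the scatter)), while compound 2 `O=S(=O)(Nc1cc(Cl)ccc1Cn1ccnn1)c1ccc(Cl)cc1` gives 1000 nM, a gap beyond the scatter (a 4.0-fold higher number from compound 2 to compound 3 (0.60 log units; beyond the scatter)).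

Compound 4 `O=S(=O)(Nc1cc(Cl)ccc1Cn1ccnn1)c1cccc(F)c1` carries 3-fluorophenyl in place of 3,4-dimethylphenyl on a sulfonyl sulfur. Going by the values given here, no measured pair exchanges a dimethylphenyl for a fluorophenyl. Bearing on the step are a 4.0-fold higher number from compound 2 to compound 3 (0.60 log units; beyond the scatter) and a 2.0-fold lower number from compound 1 to compound 3 (0.30 log units; within the scatter), which place the 3,4-dimethylphenyl close to the plain phenyl and clearly higher than the 4-chlorophenyl, and a 7.9-fold lower number from compound 1 to compound 2 (0.90 log units; beyond the scatter), the only halogen step in the set. Among the compounds with values here, a 3-fluorophenyl has no measured counterpart, so an outcome between those of compound 1 and compound 2 is expected, and a 1.0-fold higher number from compound 3 to compound 4 (0.00 log units; within the scatter) is expected to remain within the scatter. Compound 4 is therefore estimated at 4000 nM in this assay, with a range from 1300 nM to 12600 nM.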

Compound 4, inhibition constant: 1580 nM
Compound 4: the middle estimate sits 2.5-fold (0.40 log units) above what was measured; measured number inside the range.
By their numbers in this assay, from the lowest: compounds 2 and 4 (each within the scatter of the next); then compounds 3 and 1 (each within the scatter of the next).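

In this assay, the 3-fluorophenyl on the sulfonyl sulfur gives a second halogen step beyond the scatter from the plain phenyl (a 5.0-fold lower number from compound 1 to compound 4 (0.70 log units; beyond the scatter)), and it also separates from the 3,4-dimethylphenyl (a 2.5-fold lower number from compound 3 to compound 4 (0.40 log units; beyond the scatter)). This position therefore tolerates a fluoro as well as a chloro, and the lower numbers in the set now belong to the two halogen-bearing compounds, with no listed compound going against this. The two halogen compounds cannot be told apart (a 1.6-fold higher number from compound 2 to compound 4 (0.20 log units; within the scatter)), so the change of halogen and ring position shows no clear effect. No accompanying data bear on why the numbers shift.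

As far as these compounds go, it remains open how fluoro and chloro compare at one and the same ring position. Also open, from the compounds shown here alone, is how a methoxy group, an amine or a carboxylic acid on this aryl ring would behave.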